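DPP9 series: bromo for fluoro beside the carboxylic acid

This account rests on a few compounds, and the source may have more. Where it says the series, first, only, none or still open, it means among the compounds named here.

Working notes on a set of uracil-type compounds sharing one core, tested in an assay on isolated protein for inhibition of Dipeptidyl peptidase 9 (Homo sapiens), read by fluorescence, with stated times of 15 min and 20 min; on this read-out lower numbers stand for stronger inhibition and higher numbers for weaker inhibition. Compound 1 `CC#CCn1c(N2CCC[C@@H](N)C2)cc(=O)n(Cc2cccc(C(=O)O)c2F)c1=O` has no result reported, its entry reading "not determined" (no result reported). Compound 2 `CC#CCn1c(N2CCC[C@@H](N)C2)cc(=O)n(Cc2ccc(Br)c(C(=O)OC)c2)c1=O` gives only a limit in this assay, > 100 nM. Compound 3 `CC#CCn1c(N2CCC[C@@H](N)C2)cc(=O)n(Cc2ccc(F)c(C(=O)O)c2)c1=O` likewise gives only a limit, > 100 nM. Compound 3 therefore stands at the assay limit together with compound 2, and no single number separates the two; compound 1 adds nothing (the limit of > 100 nM in this assay, at which 2 of the 3 values shown sit).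

Compound 4 `CC#CCn1c(N2CCC[C@@H](N)C2)cc(=O)n(Cc2ccc(Br)c(C(=O)O)c2)c1=O` is not yet measured. It differs from compound 3 by bromo in place of fluoro on an aromatic carbon. Going by the values given here, no measured pair in the set isolates this change, so its size cannot be read from the data; compound 2, which carries the bromo group with a methyl ester, also sits at the limit. The expectation is that the step from compound 3 to compound 4 is a step that the limit leaves unreadable from compound 3 to compound 4, that is, none beyond the scatter, with a limit again the likeliest outcome. On that basis compound 4 is estimated at 400 nM, within 100 nM to 5000 nM.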

Compound 4, half-maximal inhibitory concentration: > 100 nM
Compound 4: a limit, no number (the forecaster's own chance of this, stated with the estimate: 80%); the middle value does not contradict the limit.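

Compound 2, compound 3 and compound 4 all give only a limit in this assay, so neither the step from compound 3 to compound 4 nor that from compound 2 to compound 4 can be read: the limit of > 100 nM in this assay, at which 3 of the 4 values shown sit.

The compounds shown leave open whether bromo and fluoro differ at all in this assay.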